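The compounds below may be only part of what the source reports. "The series", "measured", "known", "first", "only" and "open" are said of these compounds alone.

In a physicochemical assay for lipophilicity, using the shake flask method, in phosphate buffer, measured as octanol-water partition, with a stated time of 30 min, at pH 7.4 (on this read-out lower numbers stand for lower lipophilicity and higher numbers for higher lipophilicity), compound 1 `O=C1c2ccccc2CN1c1cnc(NCc2c(F)ccc3c2CCO3)n2cnnc12` gives 2.7 and compound 2 `CC1(C)CC(=O)N(c2cnc(NCc3c(F)ccc4c3CCO4)n3cnnc23)C1` gives 2, the lower of the two numbers. Compound 3 `O=C(Nc1cnc(NCc2c(F)ccc3c2CCO3)n2cnnc12)c1cccnc1` has ((pyridin-3-yl)carbonyl)amino in place of 4,4-dimethyl-2-oxopyrrolidin-1-yl on an aromatic carbon. Among the compounds with values here, the only measured step, a number 0.70 log units lower from compound 1 to compound 2 (beyond the scatter), also exchanged a group on an aromatic carbon, and it was modest. Within the data shown here, no measured compound carries the entering group, so that step is only a loose guide to size. The expected step is small: a number 0.20 log units higher from compound 2 to compound 3 (within the scatter). Compound 3 is estimated at 2.2, with an expected range from 1.6 to 2.8.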

Compound 3, distribution coefficient: 2
For compound 3 the middle estimate is 0.20 log units above the measured one, within the range that was stated.
By their numbers in this assay, from the lowest: compounds 2 and 3 (each within the scatter of the next); then compound 1.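

In this assay the change of 4,4-dimethyl-2-oxopyrrolidin-1-yl to ((pyridin-3-yl)carbonyl)amino gives no change at the digits printed from compound 2 to compound 3 (within the scatter) even though the entering group carries a hydrogen-bond donor and an aromatic ring that the leaving group lacks. The same entering group gives a number 0.70 log units lower from compound 1 to compound 3 (beyond the scatter) and so shows that a second, differently built group on this aromatic carbon also reads clearly apart from compound 1. Nothing available gives a reason for these numbers.

Still open, on these data alone, is how a plain amine or a carboxylic acid would read on this aromatic carbon.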